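Chalcone series: halogen swap on the aryl ketone

The source may report more compounds than this note shows. Statements on the series, on what has been measured and on what is new or still open speak of the compounds shown alone.

Measured so far:
compound 1 `COc1cc(-c2cc(/C=C/C(=O)c3ccc(N)cc3)[nH]n2)cc(OC)c1OC` gives -18% in a functional assay on SR cells (Homo sapiens) for cytotoxicity, read by sulforhodamine B assay, with a stated time of 48 h, tested at 10 uM; a lower number here means a stronger effect, a higher number a weaker effect of the compound at the concentration tested
compound 2 `COc1cc(-c2cc(/C=C/C(=O)c3ccc(Cl)c(Cl)c3)[nH]n2)cc(OC)c1OC` gives 8% in this assay

Compound 2 stands as the higher of the two numbers in this assay; the nearest, compound 1, lies lower by a number 26 percentage points higher from compound 1 to compound 2 (beyond the scatter). Compound 3 `COc1cc(-c2cc(/C=C/C(=O)c3ccc(F)c(F)c3)[nH]n2)cc(OC)c1OC` differs from compound 2 by 3,4-difluorophenyl in place of 3,4-dichlorophenyl on a carbonyl carbon. Within the data shown here, no measured step swaps one halogen for another; the only step known exchanges an amino-bearing ring for a dichloro ring, so nothing bears directly on this change. A step within the scatter is therefore expected, a number 3 percentage points lower from compound 2 to compound 3 (within the scatter). Compound 3 is estimated at 5%, between -15% and 25%.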

Compound 3, a percentage reported as activity, at one concentration (the size of the read-out at that concentration, not a potency): 11%
Compound 3: middle estimate off by 6 percentage points, on the low side, and the stated range covers the measured number.
By their numbers in this assay, from the lowest: compound 1; then compounds 2 and 3 (each within the scatter of the next).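

In this assay, 3,4-difluorophenyl in place of 3,4-dichlorophenyl on a carbonyl carbon gives a number 3 percentage points higher from compound 2 to compound 3 (within the scatter) and so does not separate the two halogen pairs at this position. The gap to the amino-bearing ring holds for the second halogen pair too, with a number 29 percentage points higher from compound 1 to compound 3 (beyond the scatter) and compound 1 apart from both halogenated compounds. No evidence on the cause of either step is available.

Still open, from the compounds shown here alone, is whether the gap follows the amine itself or the absence of halogen. A hydroxyl, an acetamide or a single bromine on this ring would bear on that.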